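A few compounds are considered here, and "the series" means these few. Any claim that something is new, unique, unknown or untested is made for them only; others in the source may bear on it.

Measured so far in a physicochemical assay for solubility, read by HPLC, with a stated time of 24 h; on this read-out higher numbers stand for higher solubility and lower numbers for lower solubility:
- compound 1, `COC(=O)CC1CCN(C[C@H]2CN(c3ccc(-n4cc(-c5ccccn5)cn4)c(F)c3)C(=O)O2)CC1`, gives 92100 nM
- compound 2, `O=C1CCC(=O)N1C[C@H]1CN(c2ccc(-n3cc(-c4ccccn4)cn3)c(F)c2)C(=O)O1`, gives 45300 nM
- compound 3, `O=C(OC[C@H]1CN(c2ccc(-n3cc(-c4ccccn4)cn3)c(F)c2)C(=O)O1)c1ccccc1`, gives only a limit of the assay, <= 65400 nM

Compound 1 holds the highest of the two plain numbers. Its nearest neighbour is compound 2, reached by a 2.0-fold lower number from compound 1 to compound 2 (0.31 log units; beyond the scatter). Compound 3 sits at the limit of <= 65400 nM in this assay, at which 1 of the 3 values shown sits, so its value is a limit and not a number. The step to it reads an at least 1.4-fold lower number from compound 1 to compound 3 (0.14 log units; that floor lies within the scatter), and the step that the limit leaves unreadable from compound 2 to compound 3.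

The new compound, compound 4, has the structure `CCC(=O)NC[C@H]1CN(c2ccc(-n3cc(-c4ccccn4)cn3)c(F)c2)C(=O)O1`. It differs from compound 1 in one place: propanoylamino in place of 4-((methoxycarbonyl)methyl)piperidin-1-yl on a saturated chain carbon bound to a saturated ring carbon. Both measured steps away from compound 1 replaced the same group at the same place and both went downward, one modestly and beyond the scatter, the other only to a limit. The same direction is expected here, as a modest drop of about the size seen for compound 2, a 1.8-fold lower number from compound 1 to compound 4 (0.27 log units; within the scatter). Compound 4 is therefore expected to give about 50000 nM in this assay, with a plausible range from 25000 nM to 95000 nM.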

Compound 4, solubility: 147000 nM
Compound 4: the middle estimate sits 2.9-fold (0.47 log units) below what was measured, outside the stated range (above it).
By their numbers in this assay, from the lowest: compound 2; then compounds 1 and 4 (each within the scatter of the next).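

Until now, every step away from the 4-((methoxycarbonyl)methyl)piperidin-1-yl group of compound 1 had pointed downward, but propanoylamino, which has no ring and carries a hydrogen-bond donor, leaves the read-out within the scatter of compound 1: a 1.6-fold higher number from compound 1 to compound 4 (0.20 log units; within the scatter). Losing that group is therefore not enough to lower the number at this position, and what replaces it counts: propanoylamino in place of 2,5-dioxopyrrolidin-1-yl gives a 3.2-fold higher number from compound 2 to compound 4 (0.51 log units; beyond the scatter), and in place of benzoyloxy it gives an at least 2.2-fold higher number from compound 3 to compound 4 (0.35 log units; beyond the scatter). The second of these steps rests on a limit for compound 3, not on a number: the limit of <= 65400 nM in this assay, at which 1 of the 4 values shown sits.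

Going by these compounds, whether the hydrogen-bond donor or the absence of a ring goes with the higher number stays open, as the two changes travel together in compound 4. Also open, on these data alone, is how an amine, a carboxylic acid or a longer chain would read in the same place.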